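The source may hold more compounds than are shown below. What is called first, only, known or untested is meant among the compounds shown, and "the series" means these compounds.

Of the compounds shown here, two sharing one core have been measured. Compound 1 `Oc1cccc(-c2cc(-c3ccco3)cc(-c3ccccc3O)n2)c1` carries a furan-2-yl group, and in a functional assay on T47D cells (Homo sapiens) for cytotoxicity, read by CCK-8 assay (a lower number here means a stronger inhibitor, a higher number a weaker inhibitor), compound 1 gives 820 nM. Compound 2 `Oc1cccc(-c2cc(-c3ccoc3)cc(-c3ccccc3O)n2)c1` is its close relative. In this assay compound 2 gives > 50000 nM, which is a limit of the assay rather than a measured number. Among the measured compounds shown here, the single measured step is an at least 60-fold higher number from compound 1 to compound 2 (1.78 log units; beyond the scatter), and it ends at the limit of > 50000 nM in this assay, at which 1 of the 2 values shown sits. Compound 2 thus stands at the weak end of what has been measured, without a number of its own.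

Compound 3 `Oc1ccc(-c2cc(-c3ccoc3)cc(-c3cccc(O)c3)n2)cc1` has not yet been measured. It differs from compound 2 in one place: 4-hydroxyphenyl in place of 2-hydroxyphenyl on an aromatic carbon. For the measured compounds named here, no measured step concerns such a change; the one measured step, an at least 60-fold higher number from compound 1 to compound 2 (1.78 log units; beyond the scatter), concerns the furan group, not the hydroxyphenyl group, so it does not bear on it. Going by the values given here, with no guiding step, and with compound 2 already at a limit, no step beyond the scatter can be predicted in either direction in this assay, and the expected step is a step that the limit leaves unreadable from compound 2 to compound 3. Compound 3 is therefore expected to give about 60000 nM in this assay, within a range from 15000 nM to 250000 nM, and most likely again reported only as a limit.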

Compound 3, half-maximal inhibitory concentration: 2610 nM
Beside the measured number, compound 3's estimate is 23-fold (1.36 log units) above it; measured number below the stated range.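

This result shows that the hydroxyphenyl group next to the ring nitrogen matters as much as the furan group did: in this assay, swapping 2-hydroxyphenyl for 4-hydroxyphenyl gives an at least 19-fold lower number from compound 2 to compound 3 (1.28 log units; beyond the scatter). The two groups have the same atoms and differ only in where the hydroxyl sits on the phenyl ring, so that placement alone separates a compound with a measurable number from one without, and a furan-3-yl group does not by itself leave a compound at the weak end. The true size of this step stays unknown, as it is counted from a value that is only a limit of the assay: the limit of > 50000 nM in this assay, at which 1 of the 3 values shown sits.

The compounds shown leave open whether 4-hydroxyphenyl would change the number in the same way on a compound carrying furan-2-yl, since the effect of one group may depend on the other. They also leave open whether the hydroxyl of the 4-hydroxyphenyl group is itself needed, which a methoxy group or an amine in its place would help to answer.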